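A few compounds are considered here, and "the series" means these few. Any claim that something is new, unique, unknown or untested is made for them only; others in the source may bear on it.

Measured compounds:
compound 1 `COc1cc2c(Nc3ccc(C#N)cc3)ncnc2cc1OCCCN1CCCC1` with 8080 nM in a functional assay on SH-SY5Y cells (Homo sapiens) for antiproliferative activity, read by MTT assay, with a stated time of 72 h; a lower number here means a stronger inhibitor, a higher number a weaker inhibitor;
compound 2 `COc1cc2c(Nc3ccc(C#N)cc3)ncnc2cc1OCCCN1CCC(CO)CC1` with 21600 nM in this assay.

For the measured compounds named here, compound 2 has the higher of the two numbers, and the only step so far, a 2.7-fold higher number from compound 1 to compound 2 (0.43 log units; beyond the scatter), runs toward it. Compound 3 `CCOC(=O)C1CCN(CCCOc2cc3ncnc(Nc4ccc(C#N)cc4)c3cc2OC)CC1` differs from compound 2 by ethoxycarbonyl in place of hydroxymethyl on a saturated ring carbon. Going by the values given here, no measured step changes a group at this spot, so the single step from compound 1 to compound 2 bears on it only loosely, as a sign that changes here stay modest. The expected step is a 1.2-fold higher number from compound 2 to compound 3 (0.06 log units; within the scatter), little beyond the scatter. Compound 3 is therefore expected to give 25000 nM, within 10000 nM to 60000 nM.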

Compound 3, half-maximal inhibitory concentration: 47200 nM
Estimate against measurement, compound 3: 1.9-fold (0.28 log units) below, and the stated range covers the measured number.
By their numbers in this assay, from the lowest: compound 1; then compound 2; then compound 3.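

In this assay, ethoxycarbonyl in place of hydroxymethyl gives a 2.2-fold higher number from compound 2 to compound 3 (0.34 log units; beyond the scatter), so the group on this saturated ring carbon does change the result, even though both groups sit on the same piperidine ring. Compared with pyrrolidin-1-yl, 4-(ethoxycarbonyl)piperidin-1-yl gives a 5.8-fold higher number from compound 1 to compound 3 (0.77 log units; beyond the scatter), and both piperidine compounds now have higher numbers than compound 1. From the compounds shown here alone, how a carboxylic acid or a primary amide at this ring carbon would compare remains open. Nothing available here explains these rises.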